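Returning From 5-Bromopyridin-2-yl to 2-Bromophenyl

The source may report more compounds than this note shows. Statements on the series, on what has been measured and on what is new or still open speak of the compounds shown alone.

Three amides sharing one core have been measured in an assay on CHO cells, read by calcium flux; on this read-out higher numbers stand for weaker inhibition and lower numbers for stronger inhibition. Compound 1 `CCc1ccc(NC(=O)c2csc(Cc3c(Cl)cccc3Cl)n2)cc1` gives 810 nM, and compound 2 `O=C(Nc1ccc(Br)cc1)c1csc(Cc2c(Cl)cccc2Cl)n1` gives 400 nM; the step of a 2.0-fold lower number from compound 1 to compound 2 (0.31 log units; beyond the scatter) is bromo in place of ethyl. Compound 3 `O=C(Nc1ccc(Br)cn1)c1csc(Cc2c(Cl)cccc2Cl)n1` reaches only a limit of the assay, > 4000 nM. The steps of an at least 4.9-fold higher number from compound 1 to compound 3 (0.69 log units; beyond the scatter) and an at least 10-fold higher number from compound 2 to compound 3 (1.00 log units; beyond the scatter) both show markedly higher numbers on moving to 5-bromopyridin-2-yl. Compound 4 `O=C(Nc1ccccc1Br)c1csc(Cc2c(Cl)cccc2Cl)n1` is not yet measured; it differs from compound 3 by 2-bromophenyl in place of 5-bromopyridin-2-yl on an amide-type nitrogen. This undoes the change that cost compound 2 its potency, though the bromine now stands as 2-bromophenyl rather than 4-bromophenyl, so the extent of recovery is uncertain. Compound 4 is therefore expected to fall by about an at least 4.0-fold lower number from compound 3 to compound 4 (0.60 log units; beyond the scatter), to an estimated 1000 nM, between 250 nM and 4000 nM.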

Compound 4, half-maximal inhibitory concentration: > 4000 nM
Compound 4 gave a limit, no number (the forecaster's own chance of this, stated with the estimate: 20%); middle value at least 4.0-fold (0.60 log units) from the limit.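

On the amide-type nitrogen in this assay, 2-bromophenyl in place of 4-bromophenyl gives an at least 10-fold higher number from compound 2 to compound 4 (1.00 log units; beyond the scatter), and 2-bromophenyl in place of 4-ethylphenyl gives an at least 4.9-fold higher number from compound 1 to compound 4 (0.69 log units; beyond the scatter). The loss seen with compound 3 therefore also occurs with a carbon-only ring, so a ring nitrogen is not required for it. The step between compound 3 and compound 4 cannot be read because both values are limits: the limit of > 4000 nM in this assay, at which 2 of the 4 values shown sit.

From the compounds shown here alone, it remains open whether unsubstituted phenyl or 3-bromophenyl on this nitrogen would give a measurable value. 2-Fluorophenyl poses the same open question.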